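From fluoro to trifluoromethyl: a tolerance question

The source may report more compounds than this note shows. Statements on the series, on what has been measured and on what is new or still open speak of the compounds shown alone.

Measured so far in an ADME assay on MDCK cells (Canis lupus familiaris) for cytotoxicity, read by MTT assay, with a stated time of 24 h (a lower number here means that less compound is tolerated, a higher number that more compound is tolerated), for three compounds:
- compound 1 `O=[N+]([O-])c1ccc(S(=O)(=O)NCc2csc3ccccc23)cc1` gives > 191000 nM as a limit
- compound 2 `O=[N+]([O-])c1ccc(S(=O)(=O)NCc2cc3ccccc3s2)cc1` gives > 191000 nM as a limit
- compound 3 `O=S(=O)(NCc1cc2ccccc2s1)c1ccc(F)cc1` gives no result ("not determined" (no result reported))

Compound 3 has no single number to stand on. Within the data shown here, the only values around it are limits and not numbers (the limit of > 191000 nM in this assay, at which 2 of the 3 values shown sit), so they give no measured step to read.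

Compound 4 `O=S(=O)(NCc1cc2ccccc2s1)c1ccc(C(F)(F)F)cc1` has not yet been measured. The change trifluoromethyl in place of fluoro on an aromatic carbon is trifluoromethyl in place of fluoro on an aromatic carbon, para to a large group.

Among the measured compounds shown here, no measured step shows what this swap does, so no step beyond the scatter is expected in this assay for this change. Compound 2, with its limit of > 191000 nM as the reference, is the nearest guide to what may follow. For compound 4, the expected half-maximal cytotoxic concentration is 170000 nM, with an estimated range from 60000 nM to 200000 nM as the likely span.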

Compound 4, half-maximal cytotoxic concentration: > 179000 nM
Compound 4: a limit, no number; the forecaster's own chance of this, stated with the estimate: 65%; middle value at least 1.0-fold (0.02 log units) away from the limit.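

In this assay compound 4 gives > 179000 nM, which is a limit and not a number. Compound 2 also stands at a limit, so no step can be read from compound 2 to compound 4. The compounds shown leave open what concentration harms these cells and whether swapping these groups changes it.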